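The compounds below may be only part of what the source reports. "The series", "measured", "known", "first", "only" and "open" are said of these compounds alone.

Measured compounds:
compound 1 `COc1ccc(/C=C(\C#N)C(=O)N/N=C(\C)c2c(O)c3ccc(O)cc3oc2=O)cc1OC` — 14300 nM
compound 2 `C/C(=N\NC(=O)/C(C#N)=C/c1ccccc1[N+](=O)[O-])c1c(O)c2ccc(O)cc2oc1=O` — 11400 nM

In a functional assay on A549 cells (Homo sapiens) for cytotoxicity, read by MTT assay, with a stated time of 24 h (on this read-out higher numbers stand for weaker inhibition and lower numbers for stronger inhibition), compound 1 gives the larger of the two numbers, yet the gap to compound 2 is small: a 1.3-fold lower number from compound 1 to compound 2 (0.10 log units; within the scatter). Compound 3 `C/C(=N\NC(=O)/C(C#N)=C/c1ccccc1Cl)c1c(O)c2ccc(O)cc2oc1=O` is not yet measured. It differs from compound 1 thus: 2-chlorophenyl in place of 3,4-dimethoxyphenyl on a double-bonded chain carbon bound to a double-bonded chain carbon. Among the measured compounds shown here, the only step that bears on this change, made in the same place, is the one from compound 1 to compound 2, which stayed within the scatter. A shift no larger than the scatter, with no set direction, is therefore expected: a 1.1-fold lower number from compound 1 to compound 3 (0.06 log units; within the scatter). Compound 3 is estimated at 12500 nM, in the range 5000 nM to 30000 nM.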

Compound 3, half-maximal inhibitory concentration: 14200 nM
For compound 3 the middle estimate is 1.1-fold (0.06 log units) below the measured one, within the range that was stated.
By their numbers in this assay, from the lowest: compounds 2, 3 and 1 (each within the scatter of the next).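

In this assay, 2-chlorophenyl at this position gives a 1.0-fold lower number from compound 1 to compound 3 (0.00 log units; within the scatter), and chloro in place of nitro on an aromatic carbon gives a 1.2-fold higher number from compound 2 to compound 3 (0.10 log units; within the scatter). Unlike 3,4-dimethoxyphenyl, the entering group has no hydrogen-bond acceptors, yet the step stays within the scatter, so all three aromatic groups now read alike here. No evidence is available to explain this result. On these data alone, whether an amine, a carboxylic acid or a longer chain in place of these aromatic groups would move the number beyond the scatter remains open.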